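The source may report more compounds than this note shows. Statements on the series, on what has been measured and on what is new or still open speak of the compounds shown alone.

Measured in a functional assay on MCF7 cells (Homo sapiens) for antiproliferative activity, read by sulforhodamine B assay, with a stated time of 48 h; a higher number here means a weaker inhibitor, a lower number a stronger inhibitor:
- compound 1 `O=C1NCCN1c1ccc(S(=O)(=O)Nc2ccc(F)c(F)c2)cc1`: 620 nM
- compound 2 `O=C1NCCN1c1ccc(S(=O)(=O)Nc2ccc(Cl)cc2)cc1`: 170 nM
- compound 3 `COc1ccc(NS(=O)(=O)c2ccc(N3CCNC3=O)cc2)cc1`: > 1000 nM

Compound 3 gives only > 1000 nM, which is a limit of this assay and not a number.

Compound 4 `COc1cccc(NS(=O)(=O)c2ccc(N3CCNC3=O)cc2)c1` carries 3-methoxyphenyl in place of 4-methoxyphenyl on a sulfonamide nitrogen.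

For the measured compounds named here, no measured step relocates a group. The nearest evidence comes from changes at the same nitrogen: a 3.6-fold lower number from compound 1 to compound 2 (0.56 log units; beyond the scatter), an at least 1.6-fold higher number from compound 1 to compound 3 (0.20 log units; that floor lies within the scatter) and an at least 5.8-fold higher number from compound 2 to compound 3 (0.76 log units; beyond the scatter). These reach only modest size, and the second has a floor within the scatter.

A step of modest size at most is therefore expected, with no firm direction. The expected step is a step that the limit leaves unreadable from compound 3 to compound 4.

For compound 4 the estimated value is 1200 nM, with an expected range of 350 nM to 5000 nM.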

Compound 4, half-maximal inhibitory concentration: 120 nM
Beside the measured number, compound 4's estimate is 10-fold (1.00 log units) above it; measured number outside the range, below it.
By their numbers in this assay, from the lowest: compounds 4 and 2 (each within the scatter of the next); then compound 1. At a limit, above all of these: compound 3.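

Swapping 4-methoxyphenyl for 3-methoxyphenyl on a sulfonamide nitrogen gives, in this assay, an at least 8.3-fold lower number from compound 3 to compound 4 (0.92 log units; beyond the scatter), so the place of the same group on this ring matters. Compound 3 marks a limit and not a number, which makes that step a floor: the limit of > 1000 nM in this assay, at which 1 of the 4 values shown sits. Against 4-chlorophenyl the change is a 1.4-fold lower number from compound 2 to compound 4 (0.15 log units; within the scatter), so the two groups cannot be separated, while against 3,4-difluorophenyl it is a 5.2-fold lower number from compound 1 to compound 4 (0.71 log units; beyond the scatter).

From the compounds shown here alone, whether chloro responds to relocation as methoxy does remains open. So does the outcome with a longer chain such as ethoxy, or with an amine or a carboxylic acid, in place of methoxy.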